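Trimethoxyphenyl benzoxazoles: replacing a dimethoxyphenyl with aminophenyl

The compounds below may be only part of what the source reports. "The series", "measured", "known", "first", "only" and "open" are said of these compounds alone.

Measured compounds:
- compound 1, `COc1ccc(-c2nc3cccc(-c4cc(OC)c(OC)c(OC)c4)c3o2)cc1OC`: 2800 nM
- compound 2, `COc1cc(-c2cccc3nc(-c4ccc(F)cc4)oc23)cc(OC)c1OC`: 8700 nM

In a functional assay on A549 cells (Homo sapiens) for antiproliferative activity, read by MTT assay, with a stated time of 48 h (on this read-out higher numbers stand for weaker inhibition and lower numbers for stronger inhibition), compound 1 gives the lowest of the two numbers shown, so it is the stronger inhibitor of the pair. Compound 2 sits a 3.1-fold higher number from compound 1 to compound 2 (0.49 log units; beyond the scatter), a modest loss that is beyond the scatter. The unmeasured compound 3, `COc1cc(-c2cccc3nc(-c4cccc(N)c4)oc23)cc(OC)c1OC`, differs from compound 1 in one place: 3-aminophenyl in place of 3,4-dimethoxyphenyl on an aromatic carbon. Among the compounds with values here, the only step that bears on this change is the one from compound 1 to compound 2, where a different group also took the place of the 3,4-dimethoxyphenyl and the number rose. A similar, modest rise is therefore expected here, though the 3-aminophenyl is not the group measured in compound 2, so the size is uncertain. Compound 3 is estimated at 5000 nM, with a range from 2000 nM to 15000 nM, which is expected to mean a 1.8-fold higher number from compound 1 to compound 3 (0.25 log units; within the scatter).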

Compound 3, half-maximal inhibitory concentration: 4700 nM
The estimate for compound 3 lay 1.1-fold (0.03 log units) above the measured number; measured number inside the range.
By their numbers in this assay, from the lowest: compounds 1, 3 and 2 (each within the scatter of the next, the first and the last beyond it).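

In this assay, the 3-aminophenyl group, with fewer heavy atoms and a hydrogen-bond donor that the 3,4-dimethoxyphenyl lacks, gives a 1.7-fold higher number from compound 1 to compound 3 (0.22 log units; within the scatter) at this carbon of the five-membered ring, so the two methoxy groups are not needed to stay within the scatter of compound 1. The change from 4-fluorophenyl gives a 1.9-fold lower number from compound 2 to compound 3 (0.27 log units; within the scatter) as well, which places compound 3 within the scatter of both earlier compounds, even though those two stand apart from each other. No measured evidence here speaks to what lies behind these numbers.

Still open, going by these compounds, is whether a 3-hydroxyphenyl, or an acetamide built on the amine, would stay within the same scatter. Also open, on these data alone, is whether a larger group at this carbon would separate clearly from compound 1.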